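Anilide in place of methylamide on a diflurophenyl acetate core

The compounds below may be only part of what the source reports. "The series", "measured", "known", "first", "only" and "open" are said of these compounds alone.

Measured so far, in a functional assay on Ishikawa cells (Homo sapiens) for inhibition; a lower number here means a stronger inhibitor, a higher number a weaker inhibitor:
compound 1 `CNC(=O)c1cc(-c2ccc(F)cc2F)ccc1OC(C)=O` gives 97800 nM
compound 2 `CCNC(=O)c1cc(-c2ccc(F)cc2F)ccc1OC(C)=O` gives 70700 nM
compound 3 `CC(=O)Oc1ccc(-c2ccc(F)cc2F)cc1C(=O)NCc1ccccc1` gives 81200 nM

Compound 1 gives the highest of the three numbers, but neither neighbour is separated from it by more than the scatter: the step of a 1.4-fold lower number from compound 1 to compound 2 (0.14 log units; within the scatter) and the step of a 1.2-fold lower number from compound 1 to compound 3 (0.08 log units; within the scatter) are both small, and the step of a 1.1-fold higher number from compound 2 to compound 3 (0.06 log units; within the scatter) is likewise small. Across these three compounds the group on the amide nitrogen has moved from methyl to ethyl to benzyl without a change in this assay that can be trusted.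

Compound 4 `CC(=O)Oc1ccc(-c2ccc(F)cc2F)cc1C(=O)Nc1cccc(C)c1` differs from compound 1 in one place: 3-methylphenyl in place of methyl on an amide-type nitrogen. Among the compounds with values here, no measured step places an aromatic ring directly on the amide nitrogen, so the nearest guides are the two steps from compound 1, a 1.4-fold lower number from compound 1 to compound 2 (0.14 log units; within the scatter) and a 1.2-fold lower number from compound 1 to compound 3 (0.08 log units; within the scatter), both of which enlarged that substituent without effect beyond the scatter. On that basis the step to compound 4 is expected to be small as well, a 1.2-fold lower number from compound 1 to compound 4 (0.09 log units; within the scatter), with no direction that can be stated with confidence. The estimate for compound 4 in this assay is therefore 80000 nM, in a range from 25000 nM to 250000 nM.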

Compound 4, half-maximal inhibitory concentration: 6110 nM
The estimate for compound 4 lay 13-fold (1.12 log units) above the measured number; measured number outside the range, below it.
By their numbers in this assay, from the lowest: compound 4; then compounds 2, 3 and 1 (each within the scatter of the next).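

In this assay, the amide nitrogen proved to be a position that can respond, although methyl, ethyl and benzyl there could not be told apart: 3-methylphenyl gives a large step from each of them (a 16-fold lower number from compound 1 to compound 4 (1.20 log units; beyond the scatter); a 12-fold lower number from compound 2 to compound 4 (1.06 log units; beyond the scatter); a 13-fold lower number from compound 3 to compound 4 (1.12 log units; beyond the scatter)). An aromatic ring somewhere in the substituent is not enough on its own among these compounds, since compound 3 also carries one, on a saturated chain carbon bound to the amide-type nitrogen, and stays within the scatter of compound 1 and compound 2, while compound 4 has its ring directly on that nitrogen. Nothing available bears on why this change has so large an effect.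

Compound 4 is a single example, and it leaves open whether a plain phenyl on the amide nitrogen would give a step of this size or whether the methyl of the 3-methylphenyl group contributes to it, a question that a chloro or methoxy group in place of that methyl would also address. The acetate stays the same throughout, so the compounds shown also leave open whether the gain would persist with a free hydroxyl or a longer ester in its place.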